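The source may report more compounds than this note shows. Statements on the series, on what has been measured and on what is new or still open speak of the compounds shown alone.

Compound 1 `COc1cc(OC)c(/C=C/S(=O)(=O)Nc2ccc(OC)c([N+](=O)[O-])c2)c(OC)c1`: 1000 nM
Compound 2 `COc1cc(OC)c(/C=C/S(=O)(=O)Nc2ccc(OC)c(NC(C)(C)C(=O)O)c2)c(OC)c1`: 5 nM

In a functional assay on K562 cells (Homo sapiens) for cytotoxicity, read by trypan blue exclusion, with a stated time of 96 h (a higher number here means a weaker inhibitor, a lower number a stronger inhibitor), compound 2 holds the lower of the two numbers at 5 nM. Among the measured compounds shown here, its only measured neighbour lies well above it, and the one measured step is a 200-fold lower number from compound 1 to compound 2 (2.30 log units; beyond the scatter), which is large and beyond the scatter. Compound 3 `COc1cc(OC)c(/C=C/S(=O)(=O)Nc2ccc(OC)c(NC(C(=O)O)c3ccc(F)cc3)c2)c(OC)c1` is not yet measured and keeps the core of compound 2. The change is carboxy(4-fluorophenyl)methyl in place of 1-carboxy-1-methylethyl on a nitrogen on an aromatic ring. For the measured compounds named here, the measured step replaced a nitro group, so it bears only loosely, and no measured step varies the group on this nitrogen. The carboxy group stays, so a small shift towards a higher number is expected, not a reversal of the large gain. The expected step is a 2.0-fold higher number from compound 2 to compound 3 (0.30 log units; within the scatter). In this assay the estimated value for compound 3 is 10 nM, with a range of 3 nM to 60 nM.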

Compound 3, half-maximal inhibitory concentration: 20 nM
Beside the measured number, compound 3's estimate is 2.0-fold (0.30 log units) below it; measured number inside the range.
By their numbers in this assay, from the lowest: compound 2; then compound 3; then compound 1.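

In this assay the group on the nitrogen on an aromatic ring can be changed without losing the gain, though the change is not free: carboxy(4-fluorophenyl)methyl in place of 1-carboxy-1-methylethyl gives a 4.0-fold higher number from compound 2 to compound 3 (0.60 log units; beyond the scatter) and so stays on the weaker side of compound 2. The comparison with the nitro compound still shows a 50-fold lower number from compound 1 to compound 3 (1.70 log units; beyond the scatter) even with a six-membered aromatic ring of carbon only added at this place, so across compound 2 and compound 3 the large gain is not tied to 1-carboxy-1-methylethyl alone. Nothing at hand gives a reason for either step.

From the compounds shown here alone, both amino substituents carry a carboxylic acid, so what an ester, a primary amide or a plain alkyl group would do on this nitrogen remains open. Also open, going by these compounds, is whether the fluorine counts, which a phenyl group without it or a 4-chlorophenyl group would settle.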